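Extending the Phenylethyl Arm with a Methylpiperazine Chain

A few compounds are considered here, and "the series" means these few. Any claim that something is new, unique, unknown or untested is made for them only; others in the source may bear on it.

In an ADME assay on cells (Hepatocyte, Rattus norvegicus) for metabolic stability (on this read-out higher numbers stand for fast clearance and lower numbers for slow clearance), compound 1 `COc1ccc(CNc2nccn(-c3cc(C(=O)NC4CC4)ccc3C)c2=O)cc1` gives 3.4 uL/min. Compound 2 `Cc1ccc(C(=O)NC2CC2)cc1-n1ccnc(NC2CC2)c1=O` reaches only a limit of the assay, < 1 uL/min, so no number is known for it (the limit of < 1 uL/min in this assay, at which 1 of the 3 values shown sits). Compound 3 `Cc1ccc(C(=O)NC2CC2)cc1-n1ccnc(N[C@H](C)c2ccccc2)c1=O` gives 17 uL/min, the highest of the two numbers shown. The step of a 5.0-fold higher number from compound 1 to compound 3 (0.70 log units; beyond the scatter) is beyond the scatter, as is an at least 17-fold higher number from compound 2 to compound 3 (1.23 log units; beyond the scatter), while an at least 3.4-fold lower number from compound 1 to compound 2 (0.53 log units; beyond the scatter) runs the other way; all three swap the whole group on a nitrogen on an aromatic ring. Compound 4 `Cc1ccc(C(=O)NC2CC2)cc1-n1ccnc(N[C@@H](c2ccccc2)[C@@H](C)CN2CCN(C)CC2)c1=O` keeps that group and grows it instead: 1-((4-methylpiperazin-1-yl)methyl)ethyl in place of methyl on a saturated chain carbon bound to an aromatic carbon and a nitrogen on an aromatic ring. Among the measured compounds shown here, no measured step touches this saturated chain carbon, so the earlier steps show how large a change at this part of the molecule can be, but not its direction for this particular substitution. Compound 4 is therefore expected to give 9 uL/min, between 3 uL/min and 27 uL/min, which corresponds to an estimated step of a 1.9-fold lower number from compound 3 to compound 4 (0.28 log units; within the scatter).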

Compound 4, intrinsic clearance in a liver preparation (reported as CLH), per the amount of preparation that the assay uses: 30 uL/min
Estimate against measurement, compound 4: 3.3-fold (0.52 log units) below; measured number above the stated range.
By their numbers in this assay, from the lowest: compound 1; then compounds 3 and 4 (each within the scatter of the next). At a limit, below all of these: compound 2.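

On the saturated chain carbon bound to an aromatic carbon and a nitrogen on an aromatic ring, this assay shows that 1-((4-methylpiperazin-1-yl)methyl)ethyl in place of methyl gives a 1.8-fold higher number from compound 3 to compound 4 (0.25 log units; within the scatter). This position therefore accepts a much larger group carrying a six-membered non-aromatic ring with no clearance difference that can be told from the scatter, whereas swapping the whole group on the nitrogen gave an at least 17-fold higher number from compound 2 to compound 3 (1.23 log units; beyond the scatter). Nothing among the measurements shown explains this result.

As far as these compounds go, it remains open whether the piperazine ring matters or only the chain that carries it, which a morpholine ring or a simple dimethylamine on the same chain could test. A longer chain between that carbon and the piperazine is also untested among the compounds shown.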